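Swapping Methyl for Acetyl on an Amide Nitrogen

This account rests on a few compounds, and the source may have more. Where it says the series, first, only, none or still open, it means among the compounds named here.

Measured compounds:
Compound 1 `CCCS(=O)(=O)N1CCN(C(C)=O)CC1` gives 0.1 mg/kg in a functional assay on the whole organism with Mus musculus as the target; a higher number here means that more compound is needed for the effect, a lower number that less compound is needed.
For compound 2 `CCCS(=O)(=O)N1CCN(C(=O)CC)C1` the result in this assay is a limit of the assay, > 10 mg/kg.
Compound 3 `CNC(=O)C1CCN(S(=O)(=O)c2ccc(F)cc2)CC1` gives 0.1 mg/kg in this assay.

Compound 3 stands level with compound 1 at the digits shown, and that difference lies within the usual scatter of this assay. The value of compound 2 is only a limit (the limit of > 10 mg/kg in this assay, at which 1 of the 3 values shown sits), so it gives no number to compare. For the measured compounds named here, no two measured compounds differ in a single place, so no measured step can guide the next one.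

Compound 4 `CC(=O)NC(=O)C1CCN(S(=O)(=O)c2ccc(F)cc2)CC1` is drawn from compound 3 by a single change: acetyl in place of methyl on an amide-type nitrogen. Methylcarbamoyl becomes acetylcarbamoyl. Without a measured step of this kind, the expected change from compound 3 to compound 4 in this assay is a modest rise in the dose needed, estimated as a 3.0-fold higher number from compound 3 to compound 4 (0.48 log units; beyond the scatter), going somewhat beyond the scatter. Compound 4 is therefore estimated at 0.3 mg/kg, with a range from 0.1 mg/kg to 3 mg/kg.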

Compound 4, minimum effective dose: 1 mg/kg
Compound 4: the middle estimate sits 3.3-fold (0.52 log units) below what was measured, and the stated range covers the measured number.
By their numbers in this assay, from the lowest: compounds 1 and 3 (each within the scatter of the next); then compound 4. At a limit, above all of these: compound 2.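

In this assay, for the compounds shown here, the group on this amide-type nitrogen clearly matters: acetyl in place of methyl gives a 10-fold higher number from compound 3 to compound 4 (1.00 log units; beyond the scatter), the first measured step in the set that changes one place only. The change raises the dose needed without removing the effect, as compound 4 still gives a measured number, 1 mg/kg, and not a limit. Nothing shown here bears on the reason for this step.

The compounds shown leave open whether the rise follows from the carbonyl that acetyl brings or simply from the larger group, a question that an ethyl group on the same nitrogen would help to settle. They also leave open whether a group such as methoxyacetyl or propionyl here would move the dose further, and whether the same swap would act alike on another core.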